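This account rests on a few compounds, and the source may have more. Where it says the series, first, only, none or still open, it means among the compounds named here.

Compound 1 `COc1ccc(-c2cc(C(=O)Nc3nc4ccc(F)cc4s3)nc3cc(-c4ccccc4)nn23)cc1OC` was tested in a functional assay on A549 cells (Homo sapiens) for cytotoxicity, read by MTT assay, with a stated time of 48 h; on this read-out lower numbers stand for stronger inhibition and higher numbers for weaker inhibition. In this assay compound 1 gives 6910 nM. Compound 2 `COc1cc(-c2cc(C(=O)Nc3nc4ccc(F)cc4s3)nc3cc(-c4ccccc4)nn23)cc(OC)c1OC` differs from it in one place: methoxy in place of hydrogen on an aromatic carbon. In this assay compound 2 gives 22400 nM, which amounts to a 3.2-fold higher number from compound 1 to compound 2 (0.51 log units; beyond the scatter). Compound 3 `COc1ccc2nc(NC(=O)c3cc(-c4ccc(OC)c(OC)c4)n4nc(-c5ccccc5)cc4n3)sc2c1` carries a different core, and the difference between the two cores is methoxy in place of fluoro on an aromatic carbon. In this assay compound 3 gives 15800 nM, a step of a 2.3-fold higher number from compound 1 to compound 3 (0.36 log units; beyond the scatter). Compound 4 `COc1ccc2nc(NC(=O)c3cc(-c4cc(OC)c(OC)c(OC)c4)n4nc(-c5ccccc5)cc4n3)sc2c1` has not yet been measured. It differs from compound 3 by methoxy in place of hydrogen on an aromatic carbon. The surroundings of the changed place read the same for both pairs, so this is the same change that turned compound 1 into compound 2, here made on the core of compound 3. Within the data shown here, only one earlier example exists, and the two cores differ, so the expectation rests on a single step. Compound 4 is expected to show a 2.8-fold higher number from compound 3 to compound 4 (0.45 log units; beyond the scatter), because the earlier step was a 3.2-fold higher number from compound 1 to compound 2 (0.51 log units; beyond the scatter). Compound 4 is therefore estimated at 45000 nM in this assay, with a likely range from 20000 nM to 100000 nM.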

Compound 4, half-maximal inhibitory concentration: 2810 nM
For compound 4 the middle estimate is 16-fold (1.20 log units) above the measured one; the whole stated range lies above it.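

In this assay, the change from 3,4-dimethoxyphenyl to 3,4,5-trimethoxyphenyl reverses direction with the core, giving a 5.6-fold lower number from compound 3 to compound 4 (0.75 log units; beyond the scatter) where it had raised the number before: the same change on two cores in this assay, a 3.2-fold higher number (0.51 log units; beyond the scatter) from compound 1 to compound 2 and a 5.6-fold lower number (0.75 log units; beyond the scatter) from compound 3 to compound 4, 18-fold (1.26 log units) apart, beyond the scatter of two such steps
The swap of fluoro for methoxy on the core likewise depends on the other group, giving an 8.0-fold lower number from compound 2 to compound 4 (0.90 log units; beyond the scatter) where it had also raised the number before: the same change on two cores in this assay, a 2.3-fold higher number (0.36 log units; beyond the scatter) from compound 1 to compound 3 and an 8.0-fold lower number (0.90 log units; beyond the scatter) from compound 2 to compound 4, 18-fold (1.26 log units) apart, beyond the scatter of two such steps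
Both comparisons rest on the same four compounds, so they are one observation: the two changes do not act independently here and neither can be carried to another core by its earlier size or direction, but these data do not show why, or whether this holds on any further core.

On these data alone, it remains open whether a chloro or methyl group in place of the methoxy on the core would also let the added methoxy lower the number. As far as these compounds go, it also remains open how an amine or a carboxylic acid in place of that added methoxy would behave on either core.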